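Side-chain exchange on compound 2: cytotoxicity notes

The source may hold more compounds than are shown below. What is called first, only, known or untested is meant among the compounds shown, and "the series" means these compounds.

Values in an ADME assay on CHO cells (Cricetulus griseus) for cytotoxicity, read by MTT assay (on this read-out higher numbers stand for lower toxicity in this test and lower numbers for higher toxicity in this test), follow
compound 1 (`CN1CCN(C2CCN(c3nccc4[nH]c(-c5cc(F)cc(F)c5)nc34)CC2)CC1`) gives 30000 nM
compound 2 (`Fc1cc(F)cc(-c2nc3c(N4CCC(CN5CCNCC5)CC4)nccc3[nH]2)c1`) gives 20000 nM

Compound 2 stands within the scatter of compound 1 on these two numbers. Compound 3 (`Fc1cc(F)cc(-c2nc3c(N4CCC(CN5CCC(F)(F)CC5)CC4)nccc3[nH]2)c1`) comes next, with this change (4,4-difluoropiperidin-1-yl in place of piperazin-1-yl on a saturated chain carbon bound to a saturated ring carbon): 4,4-difluoropiperidin-1-yl in place of piperazin-1-yl on a saturated chain carbon bound to a saturated ring carbon. Within the data shown here, the only measured step (a 1.5-fold lower number from compound 1 to compound 2 (0.18 log units; within the scatter)) makes a different exchange, stayed within the scatter and offers weak guidance. In this assay the expected change (a 1.1-fold lower number from compound 2 to compound 3 (0.05 log units; within the scatter)) is none beyond the scatter, in no clear direction. Compound 3 is estimated at 18000 nM (range 7000 nM to 45000 nM) on this read-out.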

Compound 3, half-maximal cytotoxic concentration: 26000 nM
Compound 3: the middle estimate sits 1.4-fold (0.16 log units) below what was measured; the measured number falls inside the stated range.
By their numbers in this assay, from the lowest: compounds 2, 3 and 1 (each within the scatter of the next).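

In this assay, replacing piperazin-1-yl with 4,4-difluoropiperidin-1-yl on the saturated chain carbon leaves the number within the scatter (a 1.3-fold higher number from compound 2 to compound 3 (0.11 log units; within the scatter)), even though the entering group has 0 hydrogen-bond donors. Against the 4-methylpiperazin-1-yl side chain, the (4,4-difluoropiperidin-1-yl)methyl group also stays within the scatter (a 1.2-fold lower number from compound 1 to compound 3 (0.06 log units; within the scatter)). Nothing available explains why these side chains read alike. From the compounds shown here alone, it remains open whether the fluorine atoms or the change in ring hetero atoms matters in this assay. A plain piperidin-1-yl or a morpholin-4-yl at this place would help separate the two.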